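This account rests on a few compounds, and the source may have more. Where it says the series, first, only, none or still open, it means among the compounds named here.

Measured in an ADME assay on MRC5 cells (Homo sapiens) for inhibition, with a stated time of 72 h; on this read-out lower numbers stand for an effect already at smaller amounts and higher numbers for an effect only at larger amounts of compound:
- Compound 1 `CCc1ccccc1C(=O)Nc1c[nH]nc1C(=O)N[C@H]1CC[C@H](OC)CC1` gives 3400 nM.
- Compound 2 `COc1cccc(OC)c1C(=O)Nc1c[nH]nc1C(=O)NCc1ccccn1` gives > 50000 nM, which is a limit of the assay and not a number.
- Compound 3 `CO[C@H]1CC[C@H](NC(=O)c2n[nH]cc2NC(=O)c2ccc(F)cc2F)CC1` gives 11000 nM.

Of the two numeric results, compound 3 has the higher number at 11000 nM, with compound 1 lower at 3400 nM. Also to be kept in view is the limit of > 50000 nM in this assay, at which 1 of the 3 values shown sits.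

The next compound to be read is compound 4 `CO[C@H]1CC[C@H](NC(=O)c2n[nH]cc2NC(=O)c2cc3ccccn3n2)CC1`, which keeps the rest of compound 3 and alters one group. The change is a group of 9 heavy atoms (7 carbon, 2 nitrogen; one five-membered aromatic ring with 2 hetero atoms, one six-membered aromatic ring with 1 hetero atom) in place of a group of 8 heavy atoms (6 carbon, 2 fluorine; one six-membered aromatic ring of carbon only), on a carbonyl carbon. The group leaving is the 2,4-difluorophenyl, and the group entering has no common name.

Going by the values given here, only one measured step touches this place, a 3.2-fold higher number from compound 1 to compound 3 (0.51 log units; beyond the scatter). It lies beyond the scatter but is modest, and it swaps a different pair of groups. Among the compounds with values here, with only that step from compound 1 as a guide, no direction can be favoured in this assay, and a shift larger than that modest size is not expected. The estimated step is a 1.1-fold higher number from compound 3 to compound 4 (0.04 log units; within the scatter), which is expected to stay within the scatter. Compound 4 is estimated at 12000 nM, with an expected range from 3500 nM to 38000 nM.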

Compound 4, half-maximal effective concentration: 1000 nM
Estimate against measurement, compound 4: 12-fold (1.08 log units) above; measured number outside the range, below it.
By their numbers in this assay, from the lowest: compound 4; then compound 1; then compound 3. At a limit, above all of these: compound 2.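

In this assay, going by these compounds alone, the group on this carbonyl carbon can move the number well beyond the scatter in the lower direction: an 11-fold lower number from compound 3 to compound 4 (1.04 log units; beyond the scatter), while the only earlier step at this place, a 3.2-fold higher number from compound 1 to compound 3 (0.51 log units; beyond the scatter), ran upward. The same entering group also improves on the 2-ethylphenyl, with a 3.4-fold lower number from compound 1 to compound 4 (0.53 log units; beyond the scatter), so the three groups read here on an otherwise shared structure fall in a clear order, with the group of no common name lowest, 2-ethylphenyl in the middle and 2,4-difluorophenyl highest. Nothing measured on these compounds accounts for that order.

Still open is which part of the entering group carries the step, since the compounds shown include no close comparators at this carbonyl carbon such as an unsubstituted phenyl, a pyridine or a quinoline, any of which would separate the ring nitrogens from the size of the group. Also open, as far as these compounds go, is whether the step holds when the methoxy group on the other side of the core gives way to something else, such as a hydroxyl, an amine or a carboxylic acid.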